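Swapping bromo for phenyl on the pyridine ether

This account rests on a few compounds, and the source may have more. Where it says the series, first, only, none or still open, it means among the compounds named here.

Of the compounds shown here, two have been measured in an assay on CHO-K1 cells for displacement of a labelled ligand from Orexin/Hypocretin receptor type 1 (Homo sapiens), read by radioligand binding; on this read-out higher numbers stand for weaker inhibition and lower numbers for stronger inhibition. Compound 1 `COC(=O)c1ccnc(O[C@@H]2CC[C@@H](C)N(C(=O)c3ccccc3-n3nccn3)C2)c1` gives 310 nM. Compound 2 `C[C@@H]1CC[C@@H](Oc2cc(Br)ccn2)CN1C(=O)c1ccccc1-n1nccn1` gives 130 nM, which is the lowest of the two numbers, so among the measured pair compound 2 shows the stronger inhibition. Going by the values given here, the single step that connects them, a 2.4-fold lower number from compound 1 to compound 2 (0.38 log units; beyond the scatter), exchanges a methoxycarbonyl for a bromo on an aromatic carbon and is modest in size.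

Compound 3 `C[C@@H]1CC[C@@H](Oc2cc(-c3ccccc3)ccn2)CN1C(=O)c1ccccc1-n1nccn1` has not yet been measured in this assay. It differs from compound 2 by phenyl in place of bromo on an aromatic carbon: the bromo leaves and a phenyl enters at the same aromatic carbon, meta to a large group and opposite the ring nitrogen. Among the compounds with values here, only the step from compound 1 to compound 2 bears on this position, and it concerns a different pair of groups, so there is no measured step for a bromo-to-phenyl exchange. On this thin basis the change is expected to be small, with a 1.3-fold lower number from compound 2 to compound 3 (0.11 log units; within the scatter), in this assay. Compound 3 is therefore estimated at 100 nM, with a likely range from 30 nM to 350 nM.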

Compound 3, inhibition constant: 360 nM
Compound 3: the middle estimate sits 3.6-fold (0.56 log units) below what was measured, and the stated range ends below it.
By their numbers in this assay, from the lowest: compound 2; then compounds 1 and 3 (each within the scatter of the next).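

In this assay, the aromatic carbon opposite the ring nitrogen does not take a larger group without cost: replacing the single bromine atom with the six carbons of phenyl gives a 2.8-fold higher number from compound 2 to compound 3 (0.44 log units; beyond the scatter), a modest weakening. Comparing phenyl with methoxycarbonyl at the same carbon gives a 1.2-fold higher number from compound 1 to compound 3 (0.06 log units; within the scatter), so these two quite different groups cannot be told apart here, and bromo alone stands out among the three. No measurement shown speaks to why bromo gives the lowest number.

Going by these compounds alone, only three groups have been compared at this carbon, and bromo, the one with the fewest heavy atoms, gives the lowest number, but three groups are too few to show whether the count of heavy atoms is what matters. Chloro, methyl or plain hydrogen at this carbon would test whether a still smaller group lowers the number further, while an amine or a pyridyl ring in place of phenyl would show whether a larger group must always cost strength in this series.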